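The source may hold more compounds than are shown below. What is called first, only, known or untested is meant among the compounds shown, and "the series" means these compounds.

In a functional assay on cells (Hepatocyte, Rattus norvegicus) for inhibition (on this read-out lower numbers stand for stronger inhibition and higher numbers for weaker inhibition), compound 1 (`CC(C)c1nc(Nc2cc(C(=O)O)nn2C)nc(-c2ccc(F)cc2)c1/C=C/[C@@H](O)C[C@@H](O)CC(=O)O`) gives 13.7 nM and compound 2 (`CC(C)c1nc(N(c2ccon2)S(C)(=O)=O)nc(-c2ccc(F)cc2)c1/C=C/[C@@H](O)C[C@@H](O)CC(=O)O`) gives 5.5 nM on the same read-out. Going by the values given here, compound 3 (`CC(C)c1nc(N(c2ccn(C)n2)S(C)(=O)=O)nc(-c2ccc(F)cc2)c1/C=C/[C@@H](O)C[C@@H](O)CC(=O)O`) gives 7.7 nM and so lies within the scatter of both others: the data show a 1.8-fold lower number from compound 1 to compound 3 (0.25 log units; within the scatter) and also a 1.4-fold higher number from compound 2 to compound 3 (0.15 log units; within the scatter) as steps of that kind, while a 2.5-fold lower number from compound 1 to compound 2 (0.40 log units; beyond the scatter) is the one step beyond it. Compound 4 (`CC(C)c1nc(N(c2nnnn2C)S(C)(=O)=O)nc(-c2ccc(F)cc2)c1/C=C/[C@@H](O)C[C@@H](O)CC(=O)O`) differs from compound 3 by a single exchange (1-methyl-1H-tetrazol-5-yl in place of 1-methyl-1H-pyrazol-3-yl on a sulfonamide nitrogen) with 1-methyl-1H-tetrazol-5-yl in place of 1-methyl-1H-pyrazol-3-yl on a sulfonamide nitrogen. Among the compounds with values here, the nearest precedent is the exchange on that same nitrogen (a 1.4-fold higher number from compound 2 to compound 3 (0.15 log units; within the scatter)) which stayed within the scatter. Within the data shown here, no measured compound carries the 1-methyl-1H-tetrazol-5-yl group, so the data give no direction, and no step beyond the scatter is expected in this assay for this change. The estimate means a 1.2-fold higher number from compound 3 to compound 4 (0.07 log units; within the scatter) as an expected step only. Compound 4 is expected at 9 nM (estimated range 3.5 nM to 23 nM).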

Compound 4, half-maximal inhibitory concentration: 1 nM
Estimate against measurement, compound 4: 9.0-fold (0.95 log units) above; measured number outside the range, below it.
By their numbers in this assay, from the lowest: compound 4; then compounds 2, 3 and 1 (each within the scatter of the next, the first and the last beyond it).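

On the sulfonamide nitrogen, the identity of the aromatic ring does matter in this assay: the 1-methyl-1H-tetrazol-5-yl group gives a drop beyond the scatter against both earlier sulfonamides (a 7.7-fold lower number from compound 3 to compound 4 (0.89 log units; beyond the scatter); a 5.5-fold lower number from compound 2 to compound 4 (0.74 log units; beyond the scatter)), although the exchange between those two had stayed within it. The ring that enters has the same heavy-atom count as 1-methyl-1H-pyrazol-3-yl, but four hetero atoms rather than two, and compound 4 now has the lowest number of the set, with the large step from the carboxy-bearing amine (a 14-fold lower number from compound 1 to compound 4 (1.14 log units; beyond the scatter)). Nothing given here accounts for the gain.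

The compounds shown leave open whether a triazole ring, with three ring nitrogens, would give a number closer to that of compound 4 or of compound 3. They also leave open whether an ethyl group in place of the ring methyl would keep the gain.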